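The compounds below may be only part of what the source reports. "The series", "measured", "known", "first", "only" and "open" are said of these compounds alone.

Measured so far in an assay on microsomes from brain for inhibition of Fatty-acid amide hydrolase 1 (Rattus norvegicus), read by fluorescence and HPLC, with a stated time of 60 min; on this read-out lower numbers stand for stronger inhibition and higher numbers for weaker inhibition:
compound 1 `CCCCCCCCc1ccc(OCC(=O)Cn2nnc(-c3ccncc3)n2)cc1` — 24 nM
compound 2 `CCCCCCCCc1ccc(OCC(=O)Cn2nnc(C(=O)O)n2)cc1` — 41 nM
compound 3 `CCCCCCCCc1ccc(OCC(=O)Cn2nnnc2-c2cccc(Cl)c2)cc1` — 360 nM

Compound 3 gives the highest of the three numbers in this assay; compound 2 stands nearest to it and compound 1 furthest, and both gaps lie beyond the scatter.

Compound 4 `CCCCCCCCc1ccc(OCC(=O)Cn2nnnc2-c2cccc(C(=O)O)c2)cc1` has not yet been measured. It differs from compound 3 as follows: carboxy in place of chloro on an aromatic carbon. Cut one bond further out, the change reads 3-chlorophenyl to 3-carboxyphenyl.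

For the measured compounds named here, only one measured step bears on this change, and only loosely: a 1.7-fold higher number from compound 1 to compound 2 (0.23 log units; within the scatter). There a carboxy entered on an aromatic carbon of the shared core in place of pyridin-4-yl, and the number stayed within the scatter. Going by the values given here, in compound 4 the carboxy enters instead on the six-membered aromatic ring of carbon only, in place of chloro; no measured pair shows that exchange, so the comparison is indirect. Among the compounds with values here, the one step available shows that bringing a carboxy onto this series left the number where it was, so the expectation for compound 4 is a small move at most, in no firm direction. Compound 4 is therefore expected to give about 300 nM in this assay, within a range of 100 nM to 1200 nM. That estimate corresponds to an expected step of a 1.2-fold lower number from compound 3 to compound 4 (0.08 log units; within the scatter).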

Compound 4, half-maximal inhibitory concentration: 1800 nM
The estimate for compound 4 lay 6.0-fold (0.78 log units) below the measured number; measured number outside the range, above it.
By their numbers in this assay, from the lowest: compounds 1 and 2 (each within the scatter of the next); then compound 3; then compound 4.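

In this assay the exchange of chloro for carboxy at this place, on an aromatic carbon meta to a large group, gives a 5.0-fold higher number from compound 3 to compound 4 (0.70 log units; beyond the scatter) and so moves the number towards weaker inhibition by more than the scatter. The earlier step that brought in a carboxy, a 1.7-fold higher number from compound 1 to compound 2 (0.23 log units; within the scatter) on the shared core, stayed within the scatter, so across these two pairs a carboxy has no single outcome; the pairs differ both in the group that leaves and in the ring that receives the carboxy. Nothing available accounts for the size or direction of the new step.

Whether the step comes from the loss of chloro or from the entry of carboxy stays open, since the compounds shown include no plain phenyl at this place and no methyl ester, primary amide or amine on that ring for comparison. Also open, on these data alone, is whether the exchange would give a step of similar size with a shorter chain in place of the octyl chain.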